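The compounds below may be only part of what the source reports. "The series", "measured", "known", "first", "only" and "open" are said of these compounds alone.

Of the compounds shown here, two have so far been measured in a physicochemical assay for solubility, read by spectrophotometry, in phosphate buffer, with a stated time of 2 h, at pH 7.4; a lower number here means a less soluble compound, a higher number a more soluble compound. Compound 1 `COc1ccc2[nH]c(C(=O)N3CC(=O)N(Cc4ccccc4)[C@@H](COc4ccccc4)C3)cc2c1` gives 12200 nM in this assay. Compound 2 `Cc1ccc2[nH]c(C(=O)N3CC(=O)N(Cc4ccccc4)[C@@H](CN4CCC5(CCC5)CC4)C3)cc2c1` differs from compound 1 on the shared core and in its side chain; in this assay compound 2 gives 12300 nM; the two numbers lie within the scatter of each other, so they cannot be told apart. Compound 3 `COc1ccc2[nH]c(C(=O)N3CC(=O)N(Cc4ccccc4)[C@@H](Cc4ccccn4)C3)cc2c1` is not yet measured. It differs from compound 1 in one place: pyridin-2-yl in place of phenoxy on a saturated chain carbon bound to a saturated ring carbon. Going by the values given here, no measured pair shows what such a change does in this assay, so the expectation rests on compound 1 alone. The step expected is a 1.6-fold higher number from compound 1 to compound 3 (0.21 log units; within the scatter), a small rise, not clearly beyond the scatter. Compound 3 is therefore estimated at 20000 nM, with a range from 8000 nM to 50000 nM.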

Compound 3, solubility: > 100000 nM
Compound 3 gave a limit, no number; the forecaster's own chance of this, stated with the estimate: 5%; middle value at least 5.0-fold (0.69 log units) away from the limit.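

In this assay, swapping phenoxy for pyridin-2-yl on a saturated chain carbon bound to a saturated ring carbon gives an at least 8.1-fold higher number from compound 1 to compound 3 (0.91 log units; beyond the scatter). This is the first change in a single place among the compounds shown, and it shows that this position can move the read-out well beyond the scatter. The result for compound 3 is a limit of the assay and not a number, so the true size of the step stays unknown: the limit of > 100000 nM in this assay, at which 1 of the 3 values shown sits.

The change swaps the phenoxy oxygen and carbon-only ring for a ring holding one nitrogen, and one step cannot show which of these differences matters. Going by these compounds, a phenyl group or a carboxylic acid at this place could help separate them, but how either would read here remains open.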